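Antiproliferative notes: pyridine series, step to compound 3

The source may hold more compounds than are shown below. What is called first, only, known or untested is meant among the compounds shown, and "the series" means these compounds.

Measured so far:
compound 1 `c1coc(-c2ccnc(-c3cccs3)c2)c1`, 118000 nM
compound 2 `C(=C/c1cccs1)\c1cc(-c2cccs2)cc(-c2cccs2)n1`, 118000 nM

In a functional assay on SK-OV-3 cells (Female gonad, Homo sapiens) for antiproliferative activity (on this read-out higher numbers stand for an effect only at larger amounts of compound and lower numbers for an effect already at smaller amounts), compound 1 gives 118000 nM, and in the same assay compound 2 gives 118000 nM; the two stand level within the scatter. Compound 3 `C(=C/c1ccco1)\c1cc(-c2ccco2)cc(-c2cccs2)n1` is not yet measured. It differs from compound 1 by 2-(furan-2-yl)ethenyl in place of hydrogen on an aromatic carbon. Compound 2 carries a comparable group and does not depart from compound 1, so no step beyond the scatter is expected from compound 1 to compound 3, in either direction. Compound 3 is therefore estimated at 118000 nM in this assay, with a range of 50000 nM to 280000 nM, which means an expected step of no change at the digits printed from compound 1 to compound 3 (within the scatter).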

Compound 3, half-maximal effective concentration: 118000 nM
For compound 3 middle estimate and measured number coincide at the digits printed; measured number inside the range.
By their numbers in this assay, from the lowest: compounds 1, 2 and 3 (each within the scatter of the next).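

Replacing hydrogen with 2-(furan-2-yl)ethenyl on the aromatic carbon next to the ring nitrogen gives no change at the digits printed from compound 1 to compound 3 (within the scatter) in this assay. Going by these compounds alone, this is the first single-place step read: at this position, the added five-membered aromatic ring and double bond leave the read-out unmoved. Going by these compounds, whether an amine, a carboxylic acid or a longer alkyl chain at this position would move the value remains open. No measured evidence bears on why the value holds.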